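This account rests on a few compounds, and the source may have more. Where it says the series, first, only, none or still open, it means among the compounds named here.

Measured in an ADME assay on Vero cells (Chlorocebus sabaeus) for cytotoxicity, read by MTT assay, with a stated time of 72 h; a higher number here means that more compound is tolerated, a lower number that less compound is tolerated:
- compound 1 `COc1ccc([C@H](O)COC(=O)/C=C/c2ccccc2)cc1OC`: 24300 nM
- compound 2 `COc1ccc([C@@H](O)COC(=O)/C=C/c2ccccc2)cc1OC`: 5870 nM
- compound 3 `COc1ccc([C@H](O)COC(=O)/C=C/c2ccccc2)cc1`: 33500 nM

Compound 3 stands at the tolerated end of this small set, level with compound 1: the step is a 1.4-fold higher number from compound 1 to compound 3 (0.14 log units; within the scatter). Compound 2 lies lower, at 5870 nM.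

The unmeasured compound 4 `COc1ccc([C@@H](O)COC(=O)/C=C/c2ccccc2)cc1` keeps the atoms and bonds of compound 3: the two compounds have the same atoms and bonds and differ only in configuration as drawn: 1 of 2 stereo elements differ; a stereocentre at a saturated chain carbon is drawn S in compound 3 and R in compound 4.

Among the measured compounds shown here, the closest precedent is the same change of configuration in the methoxy-bearing pair, a 4.1-fold lower number from compound 1 to compound 2 (0.62 log units; beyond the scatter), and that step is tied to the fact that compounds 1 and 2 differ only in the configuration as drawn. It is a single pair, so it fixes the direction better than the size. The step of a 1.4-fold higher number from compound 1 to compound 3 (0.14 log units; within the scatter) gives no sign that hydrogen in place of methoxy alters the picture, so the precedent is carried over. In this assay a drop of similar or slightly smaller size is expected, with the estimated step being a 3.4-fold lower number from compound 3 to compound 4 (0.53 log units; beyond the scatter). The estimate for compound 4 is 10000 nM, with an expected range of 4500 nM to 28000 nM.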

Compound 4, half-maximal cytotoxic concentration: 23300 nM
Compound 4: middle estimate off by 2.3-fold (0.37 log units), on the low side; measured number inside the range.
By their numbers in this assay, from the lowest: compound 2; then compounds 4, 1 and 3 (each within the scatter of the next).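

In this assay the change of configuration at the saturated chain carbon does not repeat its earlier size on the core without the extra methoxy: a 1.4-fold lower number from compound 3 to compound 4 (0.16 log units; within the scatter), against a 4.1-fold lower number from compound 1 to compound 2 (0.62 log units; beyond the scatter) on the methoxy-bearing core. Hydrogen in place of methoxy on an aromatic carbon, read on the pair drawn R, gives a 4.0-fold higher number from compound 2 to compound 4 (0.60 log units; beyond the scatter), so the two changes do not act independently here: the same change on two cores in this assay, a 1.4-fold higher number (0.14 log units; within the scatter) from compound 1 to compound 3 and a 4.0-fold higher number (0.60 log units; beyond the scatter) from compound 2 to compound 4, 2.9-fold (0.46 log units) apart, beyond the scatter of two such steps Compound 2, which carries the R centre together with the methoxy, is the only compound of the four that stands apart from both of its single-change neighbours.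

Going by these compounds, whether this interplay holds with a hydroxy group, a fluorine or an ethoxy group on that aromatic carbon remains open. Also open, on these data alone, is whether it survives an amide in place of the ester.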